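Stepping from compound 2 to compound 3

The source may report more compounds than this note shows. Statements on the series, on what has been measured and on what is new or still open speak of the compounds shown alone.

compound 1 `COc1ccc(-c2c(C)nc3c(N4CC[C@@H](NC(C)=O)C4)cc(C)nn23)cc1OC` gives > 95% (a limit)
compound 2 `CSc1ccc(-c2c(C)nc3c(N4CC[C@@H](NC(C)=O)C4)cc(C)nn23)cc1` gives > 95% (a limit)
compound 3 `CC(=O)N[C@@H]1CCN(c2cc(C)nn3c(-c4nccs4)c(C)nc23)C1` is not yet measured

In an ADME assay on microsomes from liver (Homo sapiens) for metabolic stability, read by LC-MS, with NADPH named in the record, with a stated time of 60 min, tested at 1 uM, in the absence of a further agent (on this read-out lower numbers stand for a less stable compound and higher numbers for a more stable compound), compound 2 gives > 95% as a limit of the assay and not a number. Compound 1 gives > 95% as a limit too. The series thus stands at the limit of > 95% in this assay, at which 2 of the 2 values shown sit, with no number yet. Among the measured compounds shown here, the one measured step is a step that the two limits leave unreadable from compound 1 to compound 2 and gives no size to carry forward. Next comes 1,3-thiazol-2-yl in place of 4-(methylsulfanyl)phenyl on an aromatic carbon with 1,3-thiazol-2-yl in place of 4-(methylsulfanyl)phenyl on an aromatic carbon. Only compound 2 at > 95% as a limit bears on the expectation. The estimate is a number at least 3 percentage points lower from compound 2 to compound 3 (that floor lies within the scatter) and is expected to be a small fall in this assay or none beyond the scatter. In this assay the estimate for compound 3 is 92% with an expected range from 78% to 100% for now.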

Compound 3, percent of the compound remaining: > 95%
Compound 3: only a limit was reported (the forecaster's own chance of this, stated with the estimate: 50%); at least 3 percentage points between middle value and limit.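

In this assay, compound 3 gives only a limit, as do compound 1 and compound 2, so no step among these compounds can be read: the limit of > 95% in this assay, at which 3 of the 3 values shown sit.

The compounds shown leave open whether 3,4-dimethoxyphenyl, 4-(methylsulfanyl)phenyl and 1,3-thiazol-2-yl differ at all in this assay.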